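A Second Benzyloxy Group on Compound 2

This account rests on a few compounds, and the source may have more. Where it says the series, first, only, none or still open, it means among the compounds named here.

Of the compounds shown here, two with a shared core have been measured in an ADME assay on L6 cells (Rattus norvegicus) for cytotoxicity, read by resazurin assay; on this read-out lower numbers stand for stronger inhibition and higher numbers for weaker inhibition. Compound 1 `N=C(N)c1ccc2[nH]c(-c3ccc4nc(-c5ccc(F)cc5)[nH]c4c3)nc2c1` gives 2.48 ug/mL. Compound 2 `N=C(N)c1ccc2[nH]c(-c3ccc4nc(-c5ccc(OCc6ccccc6)cc5)[nH]c4c3)nc2c1` gives 17.4 ug/mL, the higher of the two numbers, which makes it the weaker inhibitor of this pair.

Compound 3 `N=C(N)c1ccc2[nH]c(-c3ccc4nc(-c5ccc(OCc6ccccc6)c(OCc6ccccc6)c5)[nH]c4c3)nc2c1` keeps everything in compound 2 and adds one group. A benzyloxy group takes the place of a hydrogen on an aromatic carbon, ortho to a benzyloxy group and meta to a large group: benzyloxy in place of hydrogen on an aromatic carbon.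

Among the measured compounds shown here, only one measured step bears on this change: a 7.0-fold higher number from compound 1 to compound 2 (0.85 log units; beyond the scatter). That step also brought in a benzyloxy group, but in place of fluoro rather than hydrogen, so it is only a loose guide. With just this one step to go on, a move in the same direction in this assay is expected, though a smaller one. The expected step is a 2.3-fold higher number from compound 2 to compound 3 (0.36 log units; beyond the scatter). Compound 3 is estimated at 40 ug/mL, with an expected range of 13 ug/mL to 90 ug/mL.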

Compound 3, half-maximal inhibitory concentration: > 90 ug/mL
Compound 3 gave a limit, no number (the forecaster's own chance of this, stated with the estimate: 12%); middle value at least 2.2-fold (0.35 log units) from the limit.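

In this assay compound 3 gives > 90 ug/mL, which is a limit of the assay and not a number. The step at this position is an at least 5.1-fold higher number from compound 2 to compound 3 (0.71 log units; beyond the scatter). Its end point is a limit, and the true step may be larger than the printed size. The earlier compounds showed only a benzyloxy group replacing fluoro, whereas this result shows that a benzyloxy group replacing a hydrogen, ortho to a benzyloxy group and meta to a large group, also moves the number upward, towards weaker inhibition on this read-out, and far enough to reach the end of what the assay reports: the limit of > 90 ug/mL in this assay, at which 1 of the 3 values shown sits.

Going by these compounds, how far the number would have risen without that limit remains unknown, and so does whether the rise belongs to the benzyloxy group in particular. A methoxy group, an amine or a carboxylic acid on this same aromatic carbon would show whether other replacements of the hydrogen move the number in the same direction in this assay.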